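Notes on compound 4 against three compounds at the limit

The source may hold more compounds than are shown below. What is called first, only, known or untested is meant among the compounds shown, and "the series" means these compounds.

Compound 1 `COc1ccccc1-c1cn(C[C@H](O)[C@H]2OC(=O)C(OCc3ccccc3)=C2OCc2ccccc2)nn1`: in a functional assay on A549 cells (Homo sapiens) for antiproliferative activity, read by MTT assay, with a stated time of 72 h (a higher number here means a weaker inhibitor, a lower number a stronger inhibitor), compound 1 gives > 100000 nM, which is a limit of the assay.
Compound 2 `COc1ccc(-c2cn(C/C=C3\OC(=O)C(OCc4ccccc4)=C3OCc3ccccc3)nn2)cc1`: in this assay compound 2 gives > 100000 nM, again a limit.
Compound 3 `COc1ccccc1-c1cn(C/C=C2\OC(=O)C(OCc3ccccc3)=C2OCc2ccccc2)nn1`: in this assay compound 3 gives > 100000 nM, again a limit.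

All three values sit at the same limit (the limit of > 100000 nM in this assay, at which 3 of the 3 values shown sit). Compound 1 therefore stands nowhere on a scale of numbers; it is only known not to reach the limit, and nothing separates it from compound 2 or compound 3. Within the data shown here, the single step between neighbours that differ in one place, a step that the two limits leave unreadable from compound 2 to compound 3, is left unreadable by the two limits and gives no size.

Compound 4 `C[Si](C)(C)c1cn(C[C@H](O)[C@H]2OC(=O)C(OCc3ccccc3)=C2OCc2ccccc2)nn1` differs from compound 1 by a group of 4 heavy atoms (3 carbon, 1 silicon; no ring) in place of a group of 8 heavy atoms (7 carbon, 1 oxygen; one six-membered aromatic ring of carbon only), on an aromatic carbon. Among the measured compounds shown here, no measured step bears on this change, so no size or direction can be taken from the series. Compound 4 is expected to give about 150000 nM, with a range from 30000 nM to 1000000 nM, and most probably to be reported once more only as a limit. The expected step is a step that the limit leaves unreadable from compound 1 to compound 4, meaning no change that could be read beyond the limit.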

Compound 4, half-maximal inhibitory concentration: 19200 nM
Compound 4: middle estimate off by 7.8-fold (0.89 log units), on the high side; the measured number lies below the stated range.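

In this assay, among these compounds, the group of 4 heavy atoms (3 carbon, 1 silicon; no ring) in place of 2-methoxyphenyl gives an at least 5.2-fold lower number from compound 1 to compound 4 (0.71 log units; beyond the scatter), the first step that can be read; the steps among the earlier compounds cannot be read. An aromatic ring on this aromatic carbon is therefore not required for a value inside the range of the assay, as compound 4 shows. The step is a bound and not a measured gap, because compound 1 stands at a limit: the limit of > 100000 nM in this assay, at which 3 of the 4 values shown sit.

Compounds 1 and 4 differ in both the ring and the silicon, so a tert-butyl group, with carbon in place of silicon, would be needed to separate the two. On these data alone, whether the same silicon group gives a readable value on the core of compound 3 also stays open.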